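The source may report more compounds than this note shows. Statements on the series, on what has been measured and on what is new or still open speak of the compounds shown alone.

Measured so far: compound 1 `O=S(=O)(/C=C/c1ccc(O)c(O)c1)CC1CC1`, 10500 nM; compound 2 `CCCCCCCCCCS(=O)(=O)/C=C/c1ccc(O)c(O)c1`, 6800 nM.

In a functional assay, read by fluorescence and spectrophotometry, with a stated time of 1 h (on this read-out lower numbers stand for an effect already at smaller amounts and higher numbers for an effect only at larger amounts of compound), compound 1 gives 10500 nM, the higher of the two numbers, and compound 2 gives 6800 nM; the two lie within the scatter of each other, so they show no order. Compound 3 `O=S(=O)(/C=C/c1ccc(O)c(O)c1)CC1CCCC1` has not been measured. It differs from compound 1 in one place: cyclopentyl in place of cyclopropyl on a saturated chain carbon bound to a sulfonyl sulfur. For the measured compounds named here, with no measured step of this kind to lean on, only a small shift is expected, a 1.4-fold lower number from compound 1 to compound 3 (0.15 log units; within the scatter), not clearly beyond the scatter. Compound 3 is therefore estimated at 7500 nM, within 3500 nM to 16000 nM.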

Compound 3, half-maximal effective concentration: 9400 nM
Compound 3: middle estimate off by 1.3-fold (0.10 log units), on the low side; low and high end bracket the measured number.
By their numbers in this assay, from the lowest: compounds 2, 3 and 1 (each within the scatter of the next).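

In this assay, putting cyclopentyl in place of cyclopropyl on a saturated chain carbon bound to a sulfonyl sulfur gives a 1.1-fold lower number from compound 1 to compound 3 (0.05 log units; within the scatter), so the first step read at this position shows that the two rings cannot be told apart here. No measurement bears on why this is so.

The compounds shown leave open whether a group of another kind at this place, such as an amine or a carboxylic acid, would move the number beyond the scatter. They also leave open whether any change on the shared core would do so.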